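Swapping phenyl for benzyl on the acylsulfonamide sulfur

The compounds below may be only part of what the source reports. "The series", "measured", "known", "first", "only" and "open" are said of these compounds alone.

Of the compounds shown here, three of one family have been tested in an assay on cells for displacement of a labelled ligand from prostaglandin E2 receptor EP4 subtype (Homo sapiens), read by scintillation counting; on this read-out lower numbers stand for stronger inhibition and higher numbers for weaker inhibition. Compound 1, `Cc1oc(C(=O)NS(=O)(=O)c2ccccc2)cc1COc1ccc(-c2ccccc2)cc1`, gives 25 nM. Compound 2, `COc1ccc(-c2ccc(OCc3cc(C(=O)NS(=O)(=O)c4cccs4)oc3C)cc2)cc1`, gives 3.6 nM. Compound 3, `COc1ccc(-c2ccc(OCc3cc(C(=O)NS(=O)(=O)c4ccccc4)oc3C)cc2)cc1`, gives 5 nM. Among these three numbers compound 3 stands second highest: its nearest neighbour is compound 2, and that gap is within the scatter, while compound 1 is furthest away, beyond the scatter, as a 5.0-fold lower number from compound 1 to compound 3 (0.70 log units; beyond the scatter) shows. The comparison of compound 2 with compound 3, a 1.4-fold higher number from compound 2 to compound 3 (0.14 log units; within the scatter), tells that exchanging the ring on the sulfonyl sulfur between thiophen-2-yl and phenyl made no difference that the assay can resolve.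

Compound 4, `COc1ccc(-c2ccc(OCc3cc(C(=O)NS(=O)(=O)Cc4ccccc4)oc3C)cc2)cc1`, is not yet measured. Its change from compound 3 is benzyl in place of phenyl on a sulfonyl sulfur, so the ring is kept but moved one carbon further from the sulfonyl sulfur. Among the measured compounds shown here, only the step between compound 2 and compound 3 touches this part of the molecule, and it was within the scatter, so there is no direct guide for inserting a carbon here. The expectation is therefore a small step, if any, most likely a slightly higher number: compound 4 is estimated at 10 nM, within 3 nM to 40 nM, meaning an expected step of a 2.0-fold higher number from compound 3 to compound 4 (0.30 log units; within the scatter).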

Compound 4, inhibition constant: 3 nM
Beside the measured number, compound 4's estimate is 3.3-fold (0.52 log units) above it; the measured number falls inside the stated range.
By their numbers in this assay, from the lowest: compounds 4, 2 and 3 (each within the scatter of the next); then compound 1.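

Benzyl in place of phenyl on the sulfonyl sulfur keeps the ring but moves it one carbon further from that sulfur, and the step (a 1.7-fold lower number from compound 3 to compound 4 (0.22 log units; within the scatter)) shows no change that the assay can resolve. Benzyl in place of thiophen-2-yl reads the same way (a 1.2-fold lower number from compound 2 to compound 4 (0.08 log units; within the scatter)), so the three groups carried by compounds 2, 3 and 4 at this position all lie within the scatter of one another, and this position has now accepted a ring set one carbon further out as well as an exchange of one directly attached ring for another. Nothing measured here explains why the added carbon leaves the number unresolved.

Still open, going by these compounds, is how far this acceptance extends: a longer chain such as phenethyl, a small group with no ring such as methyl, or an amine or a carboxylic acid on the benzyl ring could each give a different number at this sulfur. Also open, on these data alone, is whether benzyl would behave the same way on compound 1, which lacks the methoxy group that compounds 2, 3 and 4 share.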